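The source may hold more compounds than are shown below. What is called first, only, known or untested is meant among the compounds shown, and "the series" means these compounds.

Measured so far in a functional assay on HeLa cells (Homo sapiens) for antiproliferative activity, read by MTT assay, with a stated time of 72 h; a lower number here means a stronger inhibitor, a higher number a weaker inhibitor:
compound 1, `O=C1O/C(=C\Cn2cc(-c3cc(F)cc(F)c3)nn2)C(OCc2ccccc2)=C1OCc1ccccc1`, gives 17700 nM;
compound 2, `C[Si](C)(C)c1cn(C[C@H](O)[C@H]2OC(=O)C(OCc3ccccc3)=C2OCc2ccccc2)nn1`, gives 22300 nM;
compound 3, `O=C1O[C@H]([C@@H](O)Cn2cc(CCO)nn2)C(OCc2ccccc2)=C1OCc1ccccc1`, gives 68800 nM.

Compound 1 has the lowest of the three numbers; compound 2 sits within the scatter of it, compound 3 beyond it. Going by the values given here, the one measured step, a 3.1-fold higher number from compound 2 to compound 3 (0.49 log units; beyond the scatter), concerns a different position and a differently built core, so it bears only loosely on the question here. Compound 4, `CCCCCc1ccc(-c2cn(C/C=C3\OC(=O)C(OCc4ccccc4)=C3OCc3ccccc3)nn2)cc1`, differs from compound 1 by 4-pentylphenyl in place of 3,5-difluorophenyl on an aromatic carbon. Among the compounds with values here, no measured pair exchanges one aryl group for another on an aromatic carbon of this kind. Within the data shown here, with no directly comparable step, the expectation in this assay is for no step beyond the scatter. The estimate for compound 4 is 15000 nM, range 5000 nM to 45000 nM, which means an expected 1.2-fold lower number from compound 1 to compound 4 (0.07 log units; within the scatter).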

Compound 4, half-maximal inhibitory concentration: > 100000 nM
Compound 4 was reported as a limit (the forecaster's own chance of this, stated with the estimate: 5%); middle value at least 6.6-fold (0.82 log units) from the limit.
By their numbers in this assay, from the lowest: compounds 1 and 2 (each within the scatter of the next); then compound 3. At a limit, above all of these: compound 4.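

In this assay, the aryl group on the aromatic carbon of the five-membered ring matters: 4-pentylphenyl in place of 3,5-difluorophenyl gives an at least 5.6-fold higher number from compound 1 to compound 4 (0.75 log units; beyond the scatter). Both groups have one six-membered aromatic ring of carbon only and no hydrogen-bond donors or acceptors, yet the step lies beyond the scatter. Compound 4 gives > 100000 nM, which is a limit and not a number: the limit of > 100000 nM in this assay, at which 1 of the 4 values shown sits.

The compounds shown do not separate the loss of the fluorine atoms from the gain of the pentyl chain. A plain phenyl, a methyl or an amine on this aryl ring would bear on that.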